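The source may report more compounds than this note shows. Statements on the series, on what has been measured and on what is new or still open speak of the compounds shown alone.

In a functional assay on NCI-H460 cells (Homo sapiens) for antiproliferative activity, read by MTT assay, with a stated time of 48 h (a lower number here means a stronger inhibitor, a higher number a weaker inhibitor), compound 1 `COc1cc(-c2cccc3nc(-c4ccccc4)oc23)cc(OC)c1OC` gives 6800 nM and compound 2 `COc1ccc(-c2nc3c(-c4cc(OC)c(OC)c(OC)c4)cccc3o2)cc1OC` gives 8900 nM. These two numbers lie within the usual scatter of repeated measurements, so they cannot be told apart, and compound 2 stands level with compound 1.

Compound 3 `COc1cc(OC)cc(-c2nc3c(-c4cc(OC)c(OC)c(OC)c4)cccc3o2)c1` has not yet been measured. It has the same atoms as compound 2, joined differently: 3,5-dimethoxyphenyl in place of 3,4-dimethoxyphenyl on an aromatic carbon. In words, 3,5-dimethoxyphenyl stands in place of 3,4-dimethoxyphenyl on an aromatic carbon of a five-membered aromatic ring with 1 nitrogen and 1 oxygen, part of a fused or bridged system of two rings.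

Among the compounds with values here, no measured pair here shows what such a swap does, so the only guide is the level set by the two known values. A change that keeps the group's size and make-up is therefore not expected to move the result beyond the scatter in this assay. The expected change is small, a 1.3-fold lower number from compound 2 to compound 3 (0.10 log units; within the scatter). For compound 3 the estimate is 7000 nM, with an expected range from 2500 nM to 18000 nM.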

Compound 3, half-maximal inhibitory concentration: 5700 nM
The estimate for compound 3 lay 1.2-fold (0.09 log units) above the measured number; low and high end bracket the measured number.
By their numbers in this assay, from the lowest: compounds 3, 1 and 2 (each within the scatter of the next).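

In this assay, putting 3,5-dimethoxyphenyl in place of 3,4-dimethoxyphenyl on an aromatic carbon of the five-membered aromatic ring with 1 nitrogen and 1 oxygen gives a 1.6-fold lower number from compound 2 to compound 3 (0.19 log units; within the scatter) and so leaves compound 2 and compound 3 indistinguishable. Within the data shown here, this is the first direct comparison at this place, since the two groups have the same atoms and differ only in how they are joined. For this pair, that rearrangement of the two methoxy groups on the phenyl ring leaves no readable mark on the result, although a single pair cannot show that this holds more widely. No measurement available here bears on what lies behind this outcome.

The compounds shown leave open whether a group of a different make-up at this place, such as an amine, a carboxylic acid or a longer chain on the phenyl ring, would shift the number beyond the scatter. They also leave open whether the same swap would stay just as silent on a different core.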